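Hydroxyphenyl isomers: estimating the 3-hydroxyphenyl member

This account rests on a few compounds, and the source may have more. Where it says the series, first, only, none or still open, it means among the compounds named here.

The series keeps a shared core and varies a hydroxyphenyl group on an aromatic nitrogen. Compound 1 `CC1(C)[C@H]2CC[C@]1(C)N(Cc1cn(-c3ccc(O)cc3)nn1)C(=O)C2` carries 4-hydroxyphenyl, and in a functional assay on LoVo cells (Homo sapiens) for inhibition, read by MTT assay, with a stated time of 24 h (a lower number here means a stronger inhibitor, a higher number a weaker inhibitor), compound 1 gives 410 nM. Compound 2 `CC1(C)[C@H]2CC[C@]1(C)N(Cc1cn(-c3ccccc3O)nn1)C(=O)C2` carries 2-hydroxyphenyl, and in this assay compound 2 gives 540 nM. Among the measured compounds shown here, these are the only two numbers available, and compound 2 stands within the scatter of compound 1, so no order can be read between them.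

Compound 3 `CC1(C)[C@H]2CC[C@]1(C)N(Cc1cn(-c3cccc(O)c3)nn1)C(=O)C2` has 3-hydroxyphenyl in place of 2-hydroxyphenyl on the same aromatic nitrogen: 3-hydroxyphenyl in place of 2-hydroxyphenyl on an aromatic nitrogen. For the measured compounds named here, one measured step bears on this change, a 1.3-fold higher number from compound 1 to compound 2 (0.12 log units; within the scatter), which is also an exchange between hydroxyphenyl isomers and stays within the scatter. Going by the values given here, no measured compound carries 3-hydroxyphenyl, so this single step is weak evidence. On that basis, no step beyond the scatter is expected in this assay, and no direction is favoured. The expected step is a 1.1-fold lower number from compound 2 to compound 3 (0.06 log units; within the scatter), which is within the scatter. For compound 3 the estimated value is 470 nM, with an expected range of 220 nM to 1000 nM.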

Compound 3, half-maximal inhibitory concentration: 410 nM
Compound 3: middle estimate off by 1.1-fold (0.06 log units), on the high side; measured number inside the range.
By their numbers in this assay, from the lowest: compounds 1, 3 and 2 (each within the scatter of the next).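

With 3-hydroxyphenyl now read in this assay, all three hydroxyphenyl isomers on the aromatic nitrogen can be compared: the exchange for 2-hydroxyphenyl gives a 1.3-fold lower number from compound 2 to compound 3 (0.12 log units; within the scatter), and the exchange for 4-hydroxyphenyl gives no change at the digits printed from compound 1 to compound 3 (within the scatter). Among the compounds shown here, until now only one pair of isomers could be compared, whereas all three pairs now lie within the scatter, so this assay gives no order among the 2-, 3- and 4-hydroxyphenyl groups at this position. No supporting data are available to say why the three isomers read alike.

All three compounds carry a hydroxyl on the phenyl ring, so the series shown does not tell whether the hydroxyl itself contributes to the numbers, a question that a plain phenyl, a methoxy group, an amine or a carboxylic acid at the same place would address. As far as these compounds go, it also remains open whether any exchange at this position on the aromatic nitrogen, such as a longer chain in place of the phenyl ring, would give a step beyond the scatter.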